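The source may report more compounds than this note shows. Statements on the series, on what has been measured and on what is new or still open speak of the compounds shown alone.

In a physicochemical assay for solubility, with a stated time of 24 h, at pH 2.2 (on this read-out lower numbers stand for lower solubility and higher numbers for higher solubility), compound 1 `O=C(NC[C@@H]1[C@H]2CN(C(=O)/C=C/c3cc(Cl)cc(Cl)c3)C[C@@H]12)c1ccc2[nH]c(=O)oc2c1` gives < 1 ug/mL, which is a limit of the assay and not a number. Compound 2 `O=C(NC[C@@H]1[C@H]2CN(C(=O)OCc3cc(C(F)(F)F)cc(C(F)(F)F)c3)C[C@@H]12)c1ccc2[nH]c(=O)oc2c1` gives < 1 ug/mL, again a limit. Among the compounds with values here, the series so far therefore stands at the limit of < 1 ug/mL in this assay, at which 2 of the 2 values shown sit, and no measured step gives a size for the next change. Compound 3 `Cc1ccc(COC(=O)N2C[C@@H]3[C@@H](CNC(=O)c4ccc5[nH]c(=O)oc5c4)[C@@H]3C2)nc1` differs from compound 1 on a carbonyl carbon: a group of 9 heavy atoms (7 carbon, 1 nitrogen, 1 oxygen; one six-membered aromatic ring with 1 hetero atom) in place of a group of 10 heavy atoms (8 carbon, 2 chlorine; one six-membered aromatic ring of carbon only), on a carbonyl carbon. An upward step in this assay is expected, estimated as an at least 100-fold higher number from compound 1 to compound 3 (2.00 log units; beyond the scatter). For compound 3 the estimated solubility is 100 ug/mL, with an expected range of 15 ug/mL to 600 ug/mL.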

Compound 3, solubility: > 92 ug/mL
Compound 3: no number, only a limit (the forecaster's own chance of this, stated with the estimate: 15%); the middle value lies beyond the limit too.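

Working notes: on the carbonyl carbon bonded to the amide-type ring nitrogen, this change moves the read-out in this assay, giving an at least 92-fold higher number from compound 1 to compound 3 (1.96 log units; beyond the scatter). Neither end of this step is a number, so it shows only that the position tolerates a large shift in the read-out. Compound 3 is a limit at the upper end: the limit of > 92 ug/mL in this assay, at which 1 of the 3 values shown sits.

Going by these compounds, the step swaps 2-(3,5-dichlorophenyl)ethenyl for the whole entering group at once, so the part of that group responsible stays open. On these data alone, whether an amine or a carboxylic acid on this carbonyl carbon would behave alike also stays open.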